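The source may report more compounds than this note shows. Statements on the series, on what has been measured and on what is new or still open speak of the compounds shown alone.

Three compounds have been measured in a functional assay on aorta for antagonist activity at Alpha-1D adrenergic receptor (Rattus norvegicus) (a higher number here means weaker binding, a lower number tighter binding), so far:

Compound 1 `CN(C)C(=O)c1cccnc1NCCCN1CCN(c2ccccc2OCC(C)(C)C)CC1`: 50.1 nM
Compound 2 `CN(C)C(=O)c1cccnc1NCCCN1CCN(c2ccccc2-c2ccccc2)CC1`: 63.1 nM
Compound 3 `CCCc1ccccc1N1CCN(CCCNc2ncccc2C(=O)N(C)C)CC1`: 31.6 nM

All three share the same core and differ only in the group carried on one aromatic carbon. Compound 3 gives the lowest of the three numbers, yet the steps of a 1.6-fold lower number from compound 1 to compound 3 (0.20 log units; within the scatter) and a 2.0-fold lower number from compound 2 to compound 3 (0.30 log units; within the scatter) both stay within the scatter of repeated measurements, so the three compounds cannot be told apart on these data.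

Compound 4 `CC(C)c1ccccc1N1CCN(CCCNc2ncccc2C(=O)N(C)C)CC1` has not yet been measured. It differs from compound 3 by isopropyl in place of propyl on an aromatic carbon. The measured steps that bear on this spot are a 1.3-fold higher number from compound 1 to compound 2 (0.10 log units; within the scatter), a 1.6-fold lower number from compound 1 to compound 3 (0.20 log units; within the scatter) and a 2.0-fold lower number from compound 2 to compound 3 (0.30 log units; within the scatter), each a swap at the same aromatic carbon and each within the scatter. Groups as different as neopentyloxy, phenyl and propyl at this place gave numbers that are indistinguishable; a change from propyl to isopropyl is smaller than any of those. The expectation for compound 4 is therefore a step of a 1.1-fold higher number from compound 3 to compound 4 (0.04 log units; within the scatter), with no change beyond the scatter. Compound 4 is estimated at 35 nM, between 15 nM and 80 nM.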

Compound 4, dissociation constant: 63.1 nM
Beside the measured number, compound 4's estimate is 1.8-fold (0.26 log units) below it; the measured number falls inside the stated range.
By their numbers in this assay, from the lowest: compounds 3, 1, 2 and 4 (each within the scatter of the next).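

Propyl and isopropyl hold the same three carbons joined differently, so this is the first change at this aromatic carbon that rearranges a group without altering its atoms, and in this assay it gives a 2.0-fold higher number from compound 3 to compound 4 (0.30 log units; within the scatter) and nothing more. The other two new comparisons read the same way, with no change at the digits printed from compound 2 to compound 4 (within the scatter) and a 1.3-fold higher number from compound 1 to compound 4 (0.10 log units; within the scatter) leaving all four groups at this place, neopentyloxy, phenyl, propyl and isopropyl, indistinguishable on these numbers. Branching the chain thus adds a fourth group to a set that shows no difference beyond the scatter, and no other kind of data is at hand to explain the numbers.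

What remains open is whether any group at this aromatic carbon can move the number beyond the scatter at all, as the four shown are hydrocarbon groups plus one ether. A primary amine, a carboxylic acid or a bare hydrogen at the same place would put that question to a real test, and a longer chain such as hexyl would show how much bulk the trend extends to.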